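Para substituent swaps on the shared core: cytotoxicity notes

A few compounds are considered here, and "the series" means these few. Any claim that something is new, unique, unknown or untested is made for them only; others in the source may bear on it.

Compound 3 `CCOC(=O)C12C(=O)OCC=C1COC2c1ccc(C(C)(C)C)cc1` shows in a functional assay on QGY cells (Homo sapiens) for cytotoxicity, read by MTT assay (on this read-out higher numbers stand for weaker inhibition and lower numbers for stronger inhibition), only a limit, > 1000000 nM. Compound 1 `CCOC(=O)C12C(=O)OCC=C1COC2c1ccc(F)cc1` likewise gives only a limit, > 1000000 nM. Compound 2 `CCOC(=O)C12C(=O)OCC=C1COC2c1ccc(Br)cc1` also sits at a limit, > 1000000 nM. The steps a step that the two limits leave unreadable from compound 1 to compound 2, a step that the two limits leave unreadable from compound 1 to compound 3 and a step that the two limits leave unreadable from compound 2 to compound 3 therefore carry no readable size, all three resting on (the limit of > 1000000 nM in this assay, at which 3 of the 3 values shown sit). Compound 4 `CCOC(=O)C12C(=O)OCC=C1COC2c1ccc(OC)cc1` differs from compound 3 by methoxy in place of tert-butyl on an aromatic carbon. Among the compounds with values here, no measured step bears on this change with a readable size, so neither a direction nor a magnitude can be drawn from the series. With every measured value at the limit, compound 4 is expected to remain at the limit as well, estimated at 1000000 nM with a range of 300000 nM to 3000000 nM. The step of a number no higher from compound 3 to compound 4 (the limit leaves the size open) is accordingly expected to be none beyond the scatter.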

Compound 4, half-maximal inhibitory concentration: > 1000000 nM
Compound 4: only a limit was reported (the forecaster's own chance of this, stated with the estimate: 85%); the middle value sits exactly at the limit.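

Compound 4 sits at the same limit as compound 1, compound 2 and compound 3, so no step among these compounds can be read in this assay: the limit of > 1000000 nM in this assay, at which 4 of the 4 values shown sit.

The compounds shown leave open whether any group at this place on the shared core gives a measurable value in this assay.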